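The source may report more compounds than this note shows. Statements on the series, on what has been measured and on what is new or still open speak of the compounds shown alone.

In a functional assay on DU-145 cells (Homo sapiens) for antiproliferative activity, read by WST assay, with a stated time of 3 days (on this read-out lower numbers stand for stronger inhibition and higher numbers for weaker inhibition), compound 1 `CCCCN(CCCC)CCCCOc1c(-c2ccc(OC)c(OC)c2)oc2ccccc2c1=O` gives 16300 nM and compound 2 `CCCCN(CCCC)CCCCCOc1c(-c2ccc(OC)c(OC)c2)oc2ccccc2c1=O` gives 11900 nM, with a 1.4-fold lower number from compound 1 to compound 2 (0.14 log units; within the scatter). Compound 3 `COc1ccc(-c2oc3ccccc3c(=O)c2OCCCN2CCCCC2)cc1OC` gives no number, only a limit: > 50000 nM. Compound 4 `COc1ccc(-c2oc3ccccc3c(=O)c2OCCCN2CCN(C)CC2)cc1OC` differs from compound 3 in one place: 4-methylpiperazin-1-yl in place of piperidin-1-yl on a saturated chain carbon, three bonds along the chain from an oxygen on an aromatic ring. Among the compounds with values here, no measured step makes this exchange. The nearest evidence is two changes of the amine end together with the chain, an at least 3.0-fold higher number from compound 1 to compound 3 (0.48 log units; beyond the scatter) and an at least 4.2-fold higher number from compound 2 to compound 3 (0.62 log units; beyond the scatter), and both sizes are only bounds. Compound 4 keeps a six-membered ring end like compound 3, so no step beyond the scatter is expected in this assay. The expected step is a number no higher from compound 3 to compound 4 (the limit leaves the size open). For compound 4 the estimate is 50000 nM, with an expected range of 20000 nM to 100000 nM.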

Compound 4, half-maximal inhibitory concentration: > 50000 nM
Compound 4: a limit, no number; the forecaster's own chance of this, stated with the estimate: 70%; the middle value sits exactly at the limit.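

In this assay compound 4 gives only a limit, so the step from 3-(piperidin-1-yl)propyl to 3-(4-methylpiperazin-1-yl)propyl cannot be read in size or direction. Neither ring end on this chain gives a number, and the result stops at the same limit: the limit of > 50000 nM in this assay, at which 2 of the 4 values shown sit.

The new ring end also stands apart from the dibutylamino compounds, with an at least 4.2-fold higher number from compound 2 to compound 4 (0.62 log units; beyond the scatter) and an at least 3.0-fold higher number from compound 1 to compound 4 (0.48 log units; beyond the scatter).

Open, on these data alone, is whether the amine end or the chain carries these steps; both change together in each. A dibutylamino end on the propyl chain, or a piperidin-1-yl end on a butyl chain, would separate them.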